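A few compounds are considered here, and "the series" means these few. Any claim that something is new, unique, unknown or untested is made for them only; others in the source may bear on it.

Compound 1 `CNC(=O)c1cc(C(=O)NC2CCC2)cn(Cc2cccc(NC)c2)c1=O`: 3.6
Compound 2 `CNC(=O)c1cc(C(=O)NC2CC2)cn(CC2CCCOC2)c1=O`: 2
Compound 3 `CNC(=O)c1cc(C(=O)NC2CC2)c(C)n(Cc2ccccc2)c1=O`: 2.9

Of the compounds shown here, three have so far been measured in a physicochemical assay for lipophilicity, at pH 7.4; on this read-out higher numbers stand for higher lipophilicity and lower numbers for lower lipophilicity. Compound 2 stands lowest of the three. The nearest to it is compound 3, whose number lies higher by more than the usual scatter, and the furthest is compound 1, whose number lies higher still, again beyond the scatter. No two of these measured compounds differ from each other in only one place, so no single structural step can be read off among them.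

Compound 4 `CNC(=O)c1cc(C(=O)NC2CC2)cn(CC2CCOCC2)c1=O` is the next compound to be measured in this assay. It is made of the same atoms as compound 2, joined differently: oxan-4-yl in place of oxan-3-yl on a saturated chain carbon bound to an aromatic nitrogen. The ring that leaves and the ring that enters are the same ring, attached at a different carbon, and both carry the same one hetero atom.

Within the data shown here, nothing among the measured compounds shows what such a move does, so the plainest expectation is a step of no size beyond the scatter, in either direction. Compound 4 is therefore expected to give 2, within a range from 1.6 to 2.4. The expected step, no change at the digits printed from compound 2 to compound 4 (within the scatter), is estimated to lie within the scatter.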

Compound 4, distribution coefficient: 1.5
Estimate against measurement, compound 4: 0.50 log units above, and the stated range ends above it.
By their numbers in this assay, from the lowest: compound 4; then compound 2; then compound 3; then compound 1.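

At the place on a saturated chain carbon bound to an aromatic nitrogen, this assay responds to where a ring is attached and not only to what the ring contains: oxan-4-yl in place of oxan-3-yl gives a number 0.50 log units lower from compound 2 to compound 4 (beyond the scatter) with no atom gained or lost. Among these compounds, the two groups match in heavy atoms, ring size, hetero atoms, hydrogen-bond donors and hydrogen-bond acceptors, so a simple tally of these features would not have told them apart, and this pair gives the first single-place comparison in the set. Nothing measured here accounts for the step, which stands as an observation from one pair of compounds.

As far as these compounds go, it remains open whether moving the attachment point has a similar effect with other saturated rings, such as piperidin-4-yl and piperidin-3-yl, which carry an amine nitrogen in place of the ring oxygen. Also open, from the compounds shown here alone, is how either oxane compares with cyclohexyl, an all-carbon ring, at this place, and whether the step would hold with the other groups found on the shared core.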